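The source may hold more compounds than are shown below. What is called first, only, known or untested is meant among the compounds shown, and "the series" means these compounds.

Compound 1 `O=[N+]([O-])c1ccccc1CNc1cc(C(F)(F)F)cc2[nH]ncc12` is the parent of this set. In an assay for inhibition of Tryptophan 2,3-dioxygenase (Homo sapiens), with stated times of 10 min and 60 min (on this read-out higher numbers stand for weaker inhibition and lower numbers for stronger inhibition), compound 1 gives 2550 nM, the second highest of the three numbers. Compound 2 `O=[N+]([O-])c1cc(Cl)ccc1CNc1cc(C(F)(F)F)cc2[nH]ncc12` gives 1700 nM; the step of a 1.5-fold lower number from compound 1 to compound 2 (0.18 log units; within the scatter) is within the scatter. Compound 3 `O=[N+]([O-])c1cc(OCc2ccccc2)ccc1CNc1cc(C(F)(F)F)cc2[nH]ncc12` gives 97000 nM; the step of a 38-fold higher number from compound 1 to compound 3 (1.58 log units; beyond the scatter) is large, as is a 57-fold higher number from compound 2 to compound 3 (1.76 log units; beyond the scatter). Compound 4 `COC(=O)c1cc(NCc2ccccc2[N+](=O)[O-])c2cn[nH]c2c1` differs from compound 1 by methoxycarbonyl in place of trifluoromethyl on an aromatic carbon. Going by the values given here, every measured step alters the part of the molecule away from the shared core, and none touches the core itself, so no measured step bears on this change. The expected step in this assay is therefore none beyond the scatter, with wide uncertainty. Compound 4 is estimated at 3000 nM, with a range of 800 nM to 12000 nM, an expected step of a 1.2-fold higher number from compound 1 to compound 4 (0.07 log units; within the scatter).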

Compound 4, half-maximal inhibitory concentration: > 100000 nM
Compound 4: no number, only a limit (the forecaster's own chance of this, stated with the estimate: 5%); middle value at least 33-fold (1.52 log units) from the limit.
By their numbers in this assay, from the lowest: compounds 2 and 1 (each within the scatter of the next); then compound 3. At a limit, above all of these: compound 4.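

Replacing trifluoromethyl on the shared core with methoxycarbonyl gives an at least 39-fold higher number from compound 1 to compound 4 (1.59 log units; beyond the scatter) in this assay, so this aromatic carbon is sensitive to substitution. Large losses are therefore not confined to the part away from the shared core, where benzyloxy gave a 38-fold higher number from compound 1 to compound 3 (1.58 log units; beyond the scatter). Compound 4 stands at a limit of the assay, not a number: the limit of > 100000 nM in this assay, at which 1 of the 4 values shown sits.

As far as these compounds go, the full size of the step stays open with only that limit. Also open, from the compounds shown here alone, is how this carbon responds to a carboxylic acid, a primary amide, a nitrile or a methyl group.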